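The source may report more compounds than this note shows. Statements on the series, on what has been measured and on what is new or still open speak of the compounds shown alone.

Compound 1, `C=C1CC[C@H]2[C@@](C)(CCC(=O)N[C@@]2(C)CO)[C@@H]1/C=C/C1=CCOC1=O`, gives in an assay for inhibition of hexokinase-2 (Homo sapiens), read by coupled enzyme assay, with a stated time of 10 min, in the presence of a further agent that is not named here (a higher number here means a weaker inhibitor, a lower number a stronger inhibitor), only the assay's limit, > 50000 nM.
Compound 2, `C=C1CC[C@H]2[C@@](C)(CCC(=O)N[C@@]2(C)COC(=O)c2ccc([N+](=O)[O-])cc2)[C@@H]1/C=C/C1=CCOC1=O`, gives in this assay only the limit, > 50000 nM.
Compound 3, `C=C1CC[C@H]2[C@@](C)(CC[C@@H](OC(=O)c3cccnc3)[C@@]2(C)NC=O)[C@@H]1/C=C/C1=CCOC1=O`, gives in this assay only the limit, > 50000 nM.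

None of the three measured compounds has a real number in this assay: each sits at the limit of > 50000 nM in this assay, at which 3 of the 3 values shown sit, so compound 3 cannot be placed against the others beyond saying that all three are at the limit.

Compound 4, `C=C1CC[C@H]2[C@@](C)(CC[C@@H](OC(=O)CNC)[C@@]2(C)NC=O)[C@@H]1/C=C/C1=CCOC1=O`, differs from compound 3 in one place: (methylamino)methyl in place of pyridin-3-yl on a carbonyl carbon. Going by the values given here, the one measured step, a step that the two limits leave unreadable from compound 1 to compound 2, also changes the group carried on an ester oxygen, but both of its ends are limits, so its size is not readable and it gives no usable guide to the direction or size of the step from compound 3 to compound 4.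

With every shown value at the limit and the one related step unreadable, the expectation for compound 4 is simply that it will also be reported at the limit, and the expected step that the limit leaves unreadable from compound 3 to compound 4 is therefore taken as none beyond the scatter.

Compound 4 is estimated at 60000 nM in this assay, within a range of 20000 nM to 200000 nM, with a high chance that only a limit is reported.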

Compound 4, half-maximal inhibitory concentration: > 50000 nM
Compound 4 ended at the assay's limit; the forecaster's own chance of this, stated with the estimate: 85%; the middle value does not contradict the limit.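

Compound 4 gives > 50000 nM in this assay as a limit and not a number. Compound 3 stands at the same limit, so no step can be read between compound 3 and compound 4. Still open, on these data alone, is which change to the shared core, if any, would bring a compound into this assay with a real number.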